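An Ethyl Amide in Place of the Pyrrolidine

The source may report more compounds than this note shows. Statements on the series, on what has been measured and on what is new or still open speak of the compounds shown alone.

Three compounds sharing one core have been measured in an assay for inhibition of serine/threonine-protein kinase Sgk1 (Homo sapiens), with stated times of 30 min and 60 min, in the presence of a further agent that is not named here; on this read-out higher numbers stand for weaker inhibition and lower numbers for stronger inhibition:
Compound 1 `O=C(N[C@@H]1CCNC1)c1cc(-c2ccc(NS(=O)(=O)c3cccc(Cl)c3Cl)cc2)nc2[nH]ncc12`: < 1 nM, a limit of the assay rather than a number.
Compound 2 `O=C(NC1CCN(C2CC2)C1)c1cc(-c2ccc(NS(=O)(=O)c3cccc(Cl)c3Cl)cc2)nc2[nH]ncc12`: 6 nM.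
Compound 3 `O=C(NC1CCN(CC2CC2)C1)c1cc(-c2ccc(NS(=O)(=O)c3cccc(Cl)c3Cl)cc2)nc2[nH]ncc12`: 1 nM.

Compound 3 holds the lowest of the two numbers shown; compound 2 stands nearest to it, and the step of a 6.0-fold lower number from compound 2 to compound 3 (0.78 log units; beyond the scatter) is beyond the scatter. Compound 1 sits at a limit (the limit of < 1 nM in this assay, at which 1 of the 3 values shown sits), so the step of a number no lower from compound 1 to compound 3 (the limit leaves the size open) leaves its size open. Compound 4 `CCNC(=O)c1cc(-c2ccc(NS(=O)(=O)c3cccc(Cl)c3Cl)cc2)nc2[nH]ncc12` differs from compound 3 in one place: ethyl in place of 1-(cyclopropylmethyl)pyrrolidin-3-yl on an amide-type nitrogen. Every measured step alters only the substituent on the ring nitrogen while the pyrrolidine itself stays: an at least 6.0-fold higher number from compound 1 to compound 2 (0.77 log units; beyond the scatter), and the return step a 6.0-fold lower number from compound 2 to compound 3 (0.78 log units; beyond the scatter). None of them removes the ring, so they bear on the new step only loosely, though they show that this part of the molecule shifts the read-out by modest amounts. Removal of the whole ring in compound 4 is therefore expected to cost more than those changes, and the step of a 25-fold higher number from compound 3 to compound 4 (1.40 log units; beyond the scatter) is estimated to be modest to large toward a higher number. Compound 4 is expected to give about 25 nM, within 4 nM to 150 nM.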

Compound 4, half-maximal inhibitory concentration: 6 nM
Estimate against measurement, compound 4: 4.2-fold (0.62 log units) above, within the range that was stated.
By their numbers in this assay, from the lowest: compound 3; then compounds 2 and 4 (each within the scatter of the next).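

Within the data shown here, the ring is not needed to hold this position in a low range, but it is not neutral either: in this assay, a 6.0-fold higher number from compound 3 to compound 4 (0.78 log units; beyond the scatter), which is the first measure of what the whole 1-(cyclopropylmethyl)pyrrolidin-3-yl group is worth against a plain ethyl. The ring as such brings no gain in every form, for no change at the digits printed from compound 2 to compound 4 (within the scatter), so ethyl, with no ring at all, matches 1-cyclopropylpyrrolidin-3-yl, and what the ring gives depends on what its nitrogen carries, as an at least 6.0-fold higher number from compound 1 to compound 4 (0.77 log units; beyond the scatter) also suggests. Compound 1 stands at a limit and not at a number, so that last step has no upper size: the limit of < 1 nM in this assay, at which 1 of the 4 values shown sits.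

The compounds shown leave open whether the difference between ethyl and the better ring forms belongs to the amine nitrogen or to the ring carbons, which a 2-aminoethyl chain on the amide-type nitrogen would help to separate. They also say nothing of how a longer chain such as n-butyl, or a six-membered piperidin-4-yl, would read at this position.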